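Working notes: 2,5-dihydroxyphenyl in place of 4-fluorophenyl

The source may report more compounds than this note shows. Statements on the series, on what has been measured and on what is new or still open speak of the compounds shown alone.

- compound 1 `COc1cc(OC)c(OC)cc1/C=C/C(=O)c1ccc(O)cc1O`: 2.37 ug/mL
- compound 2 `COc1cc(OC)c(OC)cc1/C=C/C(=O)c1ccc(F)cc1`: 2.22 ug/mL

In a functional assay on cells (Erythrocyte, Rattus norvegicus) for inhibition, read by hemolysis, with a stated time of 1 h (a lower number here means a stronger inhibitor, a higher number a weaker inhibitor), compound 2 gives 2.22 ug/mL, within the scatter of compound 1. Compound 3 `COc1cc(OC)c(OC)cc1/C=C/C(=O)c1cc(O)ccc1O` differs from compound 2 as follows: 2,5-dihydroxyphenyl in place of 4-fluorophenyl on a carbonyl carbon. In words, this is 2,5-dihydroxyphenyl in place of 4-fluorophenyl on a carbonyl carbon. For the measured compounds named here, the only measured step bearing on it is a 1.1-fold lower number from compound 1 to compound 2 (0.03 log units; within the scatter), with 4-fluorophenyl in place of 2,4-dihydroxyphenyl at that same carbon. No shift beyond the scatter is therefore expected in this assay. The expected step is a 1.0-fold higher number from compound 2 to compound 3 (0.02 log units; within the scatter). For compound 3 the estimated value is 2.3 ug/mL, with an expected range of 1.1 ug/mL to 4.8 ug/mL.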

Compound 3, half-maximal inhibitory concentration: 2.1 ug/mL
Compound 3: middle estimate off by 1.1-fold (0.04 log units), on the high side, and the stated range covers the measured number.
By their numbers in this assay, from the lowest: compounds 3, 2 and 1 (each within the scatter of the next).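

In this assay, 2,5-dihydroxyphenyl on the carbonyl carbon gives a 1.1-fold lower number from compound 2 to compound 3 (0.02 log units; within the scatter) and a 1.1-fold lower number from compound 1 to compound 3 (0.05 log units; within the scatter). The assay therefore does not separate 4-fluorophenyl, 2,4-dihydroxyphenyl and 2,5-dihydroxyphenyl at this carbon, so the two dihydroxyphenyl isomers now add to the fluorinated group as a third case without a difference beyond the scatter. No evidence bears on this result. Open, as far as these compounds go, is whether any group at this carbon gives a step beyond the scatter, for example an aminophenyl, a carboxyphenyl or a plain alkyl chain in place of the ring.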